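The source may report more compounds than this note shows. Statements on the series, on what has been measured and on what is new or still open speak of the compounds shown alone.

Compound 1, `COc1ccccc1-n1c(SCC(=O)Nc2nc3ccc(Cl)cc3s2)nc2c(c1=O)SCC2`, and compound 2, `COc1ccc2nc(NC(=O)CSc3nc4c(c(=O)n3-c3ccccc3OC)SCC4)sc2c1`, share one core and differ in a single spot. In an assay on L cells for inhibition of Protein-serine O-palmitoleoyltransferase porcupine (Mus musculus), read by reporter gene assay, with a stated time of 24 h (a higher number here means that more compound is needed for the effect, a lower number that less compound is needed), compound 1 gives 50 nM. In this assay compound 2 gives 50 nM. The change between them, (methoxy in place of chloro on an aromatic carbon), made a step of no change at the digits printed from compound 1 to compound 2 (within the scatter), so swapping the chloro for the methoxy on the 6-chloro-1,3-benzothiazol-2-yl group left the read-out where it was.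

Compound 3, `O=C(CNC(=O)c1nn(-c2ccc(F)cc2)c(=O)c2ccccc12)Nc1nc2ccc(Cl)cc2s1`, is built on a different core; the difference between the two cores is not broken down here. In this assay compound 3 gives 25 nM, a number that sits close to those of compound 1 and compound 2 and within the usual scatter of them.

Compound 4, `COc1ccc2nc(NC(=O)CNC(=O)c3nn(-c4ccc(F)cc4)c(=O)c4ccccc34)sc2c1`, has not yet been measured. It stands to compound 3 as compound 2 stands to compound 1: methoxy in place of chloro on an aromatic carbon. The place of the change is described in the same words for both pairs, so this is the same change, made on another core.

Because the same change gave no change at the digits printed from compound 1 to compound 2 (within the scatter), the step from compound 3 to compound 4 is expected to be no change at the digits printed from compound 3 to compound 4 (within the scatter). Compound 4 is therefore estimated to give 25 nM in this assay, with an expected range from 10 nM to 60 nM.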

Compound 4, half-maximal effective concentration: 90 nM
For compound 4 the middle estimate is 3.6-fold (0.56 log units) below the measured one; the measured number lies above the stated range.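

Methoxy in place of chloro did not carry over unchanged from one core to the other in this assay, and the two steps differ by more than the usual scatter: the same change on two cores in this assay, no change at the digits printed (within the scatter) from compound 1 to compound 2 and a 3.6-fold higher number (0.56 log units; beyond the scatter) from compound 3 to compound 4, 3.6-fold (0.56 log units) apart, beyond the scatter of two such steps

On the core shared by the later pair, the swap gave a 3.6-fold higher number from compound 3 to compound 4 (0.56 log units; beyond the scatter), so a result for this change on one core is not a safe guide to its result on the other in this series. Among the compounds shown here, this rests on only one pair of compounds for each core, and it does not show which part of the cores lies behind the difference, nor how the change would behave on any third core.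

The compounds shown leave open how other groups at the same place on the 1,3-benzothiazol-2-yl group, such as an amine, a carboxylic acid or a longer chain like ethoxy, would compare on the two cores. They also leave open whether plain hydrogen at that place would separate the two cores in the same way, which would help to show whether chloro and methoxy each differ from an unsubstituted ring.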